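The source may hold more compounds than are shown below. What is called first, only, known or untested is meant among the compounds shown, and "the series" means these compounds.

In an ADME assay on microsomes from liver (Homo sapiens) for metabolic stability, with a stated time of 60 min, tested at 10 uM (on this read-out higher numbers stand for a more stable compound and lower numbers for a less stable compound), compound 1 (`CCCS(=O)(=O)N1CCN(C2(CNC(=O)c3ccccc3C(F)(F)F)CCCCC2)CC1`) gives 5% and compound 2 (`CCCS(=O)(=O)N1CCN(C2(CNC(=O)c3ccccc3OC(F)(F)F)CCCCC2)CC1`) gives 2%, so these two cannot be told apart. Compound 3 (`CCCS(=O)(=O)N1CCN(C2(CNC(=O)c3ccc(OC(F)(F)F)cc3)CCCCC2)CC1`) has the same atoms as compound 2, joined differently: 4-(trifluoromethoxy)phenyl in place of 2-(trifluoromethoxy)phenyl on a carbonyl carbon. Going by the values given here, only one measured step bears on this change, and only loosely: a number 3 percentage points lower from compound 1 to compound 2 (within the scatter), with trifluoromethoxy in place of trifluoromethyl. Among the compounds with values here, no measured step shows what this new change does, and the one available is small, so the expected result is a number 3 percentage points higher from compound 2 to compound 3 (within the scatter), with no shift beyond the scatter. Compound 3 is estimated at 5%, within a range of 1% to 20%.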

Compound 3, percent of the compound remaining: 11%
The estimate for compound 3 lay 6 percentage points below the measured number, within the range that was stated.
By their numbers in this assay, from the lowest: compounds 2, 1 and 3 (each within the scatter of the next).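

In this assay, 4-(trifluoromethoxy)phenyl in place of 2-(trifluoromethoxy)phenyl on the carbonyl carbon gives a number 9 percentage points higher from compound 2 to compound 3 (within the scatter) and 4-(trifluoromethoxy)phenyl in place of 2-(trifluoromethyl)phenyl gives a number 6 percentage points higher from compound 1 to compound 3 (within the scatter) on the same carbon. Neither change therefore separates these three compounds, so moving the trifluoromethoxy group around the aromatic ring shows no effect that can be told from the scatter. No measurement here offers an explanation for these numbers. Still open, from the compounds shown here alone, is whether an amine or a carboxylic acid on this aromatic ring would give a number beyond the scatter.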